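Replacing the phenyl group of compound 3

This account rests on a few compounds, and the source may have more. Where it says the series, first, only, none or still open, it means among the compounds named here.

Of the compounds shown here, three built on a shared core have been measured in an ADME assay on Caco-2 cells (Homo sapiens) for permeability, read by LC-MS, in the apical to basolateral direction, with a stated time of 60 min, at pH 6.5; a lower number here means that the compound crosses the layer more slowly, a higher number that the compound crosses the layer faster: compound 1 `Cc1cccc([C@@H](O)C(=O)N2N=CC[C@H]2C(=O)NCc2cc(Cl)ccc2-n2cnnn2)c1` gives 9.7 10^-6 cm/s, compound 2 `O=C(NCc1cc(Cl)ccc1-n1cnnn1)[C@@H]1CC=NN1C(=O)[C@H](O)c1ccccc1F` gives 8.9 10^-6 cm/s, and compound 3 `O=C(NCc1cc(Cl)ccc1-n1cnnn1)[C@@H]1CC=NN1C(=O)[C@H](O)c1ccccc1` gives 7 10^-6 cm/s. These three values lie within the scatter of one another, so compound 3 stands level with the other two.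

The next compound, compound 4 `CC1(C[C@@H](O)C(=O)N2N=CC[C@H]2C(=O)NCc2cc(Cl)ccc2-n2cnnn2)CC1`, differs from compound 3 on a saturated chain carbon bound to a carbonyl carbon and an oxygen on a saturated carbon: (1-methylcyclopropyl)methyl in place of phenyl on a saturated chain carbon bound to a carbonyl carbon and an oxygen on a saturated carbon. The closest evidence comes from small edits to the aromatic group at that place: a 1.4-fold lower number from compound 1 to compound 3 (0.14 log units; within the scatter), a 1.3-fold lower number from compound 2 to compound 3 (0.10 log units; within the scatter) and a 1.1-fold lower number from compound 1 to compound 2 (0.04 log units; within the scatter). All three are within the scatter. However, every measured compound keeps an aromatic group there, so the data offer no direct precedent for removing it.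

No step beyond the scatter is therefore expected, though with little confidence. In this assay the expected step is a 1.1-fold higher number from compound 3 to compound 4 (0.06 log units; within the scatter). For compound 4 the estimated value is 8 10^-6 cm/s, with an expected range from 3.5 10^-6 cm/s to 16 10^-6 cm/s.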

Compound 4, apparent permeability: 9.5 10^-6 cm/s
For compound 4 the middle estimate is 1.2-fold (0.07 log units) below the measured one, within the range that was stated.
By their numbers in this assay, from the lowest: compounds 3, 2, 4 and 1 (each within the scatter of the next).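

In this assay, the step from an aromatic group to a non-aromatic one at this place is small: a 1.4-fold higher number from compound 3 to compound 4 (0.13 log units; within the scatter), a 1.1-fold higher number from compound 2 to compound 4 (0.03 log units; within the scatter) and a 1.0-fold lower number from compound 1 to compound 4 (0.01 log units; within the scatter), all within the scatter. The earlier compounds shown here all kept an aromatic ring here, so they could show only that small edits to that ring left the number level; compound 4 shows that, in this series, the whole phenyl ring can give way to (1-methylcyclopropyl)methyl with the same outcome. Nothing measured here offers an explanation for this result.

All four compounds carry only a phenyl, a substituted phenyl or (1-methylcyclopropyl)methyl at this place. On these data alone, how an amine, a carboxylic acid or a longer chain would behave there remains open.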